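The source may hold more compounds than are shown below. What is called first, only, known or untested is meant among the compounds shown, and "the series" means these compounds.

Measured so far:
Compound 1 `Cc1cc(-n2ccc3cccnc32)cn2c(CSCCc3ccccc3)cnc12`: 16 ug/mL
Compound 2 `Cc1cc(N2CCCC2)c2ncc(CSCCc3ccccc3)n2c1`: > 100 ug/mL
Compound 3 `Cc1cc(N2CCCC2)c2ncc(CSCc3ccccc3)n2c1`: 52 ug/mL

These three compounds were tested in an ADME assay on HEL cells (Homo sapiens) for cytotoxicity, with a stated time of 3 days; on this read-out higher numbers stand for lower toxicity in this test and lower numbers for higher toxicity in this test. Among the measured compounds shown here, compound 2 gives only a limit of the test, > 100 ug/mL, so no exact number is known for it; it is the one compound that sits at the limit of > 100 ug/mL in this assay, at which 1 of the 3 values shown sits. Compound 3 gives 52 ug/mL. Compound 1 gives 16 ug/mL.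

For the measured compounds named here, the one change measured here, an at least 1.9-fold lower number from compound 2 to compound 3 (0.28 log units; that floor lies within the scatter), shortens the chain on the sulfur and stays at the edge of the usual scatter.

Compound 4 `Cc1cc(N2CCCC2=O)c2ncc(CSCCc3ccccc3)n2c1` is not yet measured. It differs from compound 2 by 2-oxopyrrolidin-1-yl in place of pyrrolidin-1-yl on an aromatic carbon. Going by the values given here, no measured pair here changes this ring, so nothing among the three compounds shows what this change does in this assay.

Without such a comparison, the number for compound 4 is expected to stay close to where compound 2 sits, with a step of a number no higher from compound 2 to compound 4 (the limit leaves the size open) expected. Compound 4 is therefore estimated at 100 ug/mL, within a range from 40 ug/mL to 250 ug/mL, and a limit rather than a number is a real possibility.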

Compound 4, half-maximal cytotoxic concentration: 25 ug/mL
For compound 4 the middle estimate is 4.0-fold (0.60 log units) above the measured one; measured number outside the range, below it.
By their numbers in this assay, from the lowest: compounds 1 and 4 (each within the scatter of the next); then compound 3. At a limit, above all of these: compound 2.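

Placing 2-oxopyrrolidin-1-yl in place of pyrrolidin-1-yl on this aromatic carbon gives an at least 4.0-fold lower number from compound 2 to compound 4 (0.60 log units; beyond the scatter) in this assay. Among the compounds shown here, the only earlier step changed the chain on the sulfur and stayed within the scatter at its floor, whereas this pair shows that the group on this aromatic carbon can shift the read-out towards higher toxicity in this test, with the ring carbonyl as the only difference. The value for compound 2 is a limit, so this step is only a floor and its full size stays unknown: the limit of > 100 ug/mL in this assay, at which 1 of the 4 values shown sits.

On these data alone, it remains open whether other groups on this carbon, such as a piperidin-1-yl ring, a morpholin-4-yl ring or a dimethylamino group, would sit nearer compound 2 or compound 4. As far as these compounds go, it is also open whether the carbonyl would have a similar effect alongside the shorter sulfur chain of compound 3.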